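A few compounds are considered here, and "the series" means these few. Any claim that something is new, unique, unknown or untested is made for them only; others in the source may bear on it.

Of the compounds shown here, three have been measured in an ADME assay on MCF-10A cells (Homo sapiens) for cytotoxicity, read by sulforhodamine B assay, with a stated time of 48 h; on this read-out higher numbers stand for weaker inhibition of growth and lower numbers for stronger inhibition of growth. Compound 1 `CN(C)CN1C(=O)C(=O)c2c(Br)cccc21` gives 67800 nM. Compound 2 `Cc1ccc2nc(/N=C3\C(=O)N(CN4CCCCC4)c4cccc(Br)c43)sc2c1` gives 18400 nM. Compound 3 `CCN(CC)CN1C(=O)C(=O)c2c(Cl)cccc21` gives 35000 nM, the second highest of the three numbers; its nearest neighbour is compound 2, and its furthest is compound 1, and both of those gaps lie within the usual scatter, so no order among the three can be read from them.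

Compound 4 `CN(C)CN1C(=O)C(=O)c2c(Cl)cccc21` has not yet been measured in this assay. It differs from compound 3 in one place: dimethylamino in place of diethylamino on a saturated chain carbon bound to an amide-type nitrogen in a ring. Compound 1 also carries dimethylamino on a saturated chain carbon bound to an amide-type nitrogen in a ring, and in this assay compound 1 gives 67800 nM, a number close to that of compound 3. The step from diethylamino to dimethylamino is therefore expected to be small, a 1.4-fold higher number from compound 3 to compound 4 (0.14 log units; within the scatter), not beyond the scatter in either direction. Compound 4 is estimated to give 48000 nM in this assay, within a range from 20000 nM to 115000 nM.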

Compound 4, concentration for 50% growth inhibition: 82300 nM
The estimate for compound 4 lay 1.7-fold (0.23 log units) below the measured number; the range from low to high includes it.
By their numbers in this assay, from the lowest: compounds 2, 3, 1 and 4 (each within the scatter of the next, the first and the last beyond it).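

In this assay, the position carrying the amine gives its first readable step: dimethylamino in place of diethylamino on a saturated chain carbon bound to an amide-type nitrogen in a ring gives a 2.4-fold higher number from compound 3 to compound 4 (0.37 log units; beyond the scatter), a modest change that lies beyond the scatter. The earlier compounds shown here offered no pair differing in one place, and the second new pair now shows that, with dimethylamino held fixed, chloro in place of bromo on an aromatic carbon gives a 1.2-fold higher number from compound 1 to compound 4 (0.08 log units; within the scatter), so no effect of that exchange can be read. No measurement is available here that would explain either step.

The compounds shown leave open whether the amine step holds when bromo replaces chloro on the aromatic carbon. They also leave open how a longer chain such as dipropylamino or a ring amine such as morpholine would read at this place.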